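Benzylsulfanyl for ethylamino on a nucleoside core

This account rests on a few compounds, and the source may have more. Where it says the series, first, only, none or still open, it means among the compounds named here.

Of the compounds shown here, three have numbers so far in a functional assay (Homo sapiens) for inhibition of Nucleic Acid, tested at 100 uM; a higher number here means more inhibition at the concentration tested (going by the name of the read-out), a lower number less inhibition. Compound 1, `CCNc1nccc2c1ncn2C1O[C@H](CO)[C@@H](O)[C@H]1O`, gives 4%. Compound 3, `CC1OC(n2cnc3c(N)nccc32)CC1O`, gives 3%, which lies within the scatter of compound 1, so the two cannot be told apart. Compound 2, `OC[C@H]1O[C@@H](n2cnc3c(SCc4ccccc4)nccc32)C[C@@H]1O`, gives 18%, a number beyond the scatter above compound 1. Compound 1 therefore stands second highest of the three, close to compound 3 and farthest from compound 2.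

Compound 4, `OC[C@H]1OC(n2cnc3c(SCc4ccccc4)nccc32)[C@H](O)[C@@H]1O`, has not been measured. Its structure differs from compound 1 in one place: benzylsulfanyl in place of ethylamino on an aromatic carbon. For the measured compounds named here, no step between measured compounds carries this same change. Going by the values given here, the only measured compound bearing benzylsulfanyl is compound 2, which gives 18%, while compound 1 with ethylamino gives 4%; the sugar portions of compound 2 and compound 4 are not identical, so this is a hint and not a step.

The estimate for compound 4 is 12%, with a range from 0% to 30%. The expected step of a number 8 percentage points higher from compound 1 to compound 4 (within the scatter) is upward and roughly at the edge of the scatter, because compound 2 gives 18%.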

Compound 4, a percentage reported as inhibition, at one concentration (the size of the read-out at that concentration, not a potency): 30%
Compound 4: middle estimate off by 18 percentage points, on the low side; the measured number falls inside the stated range.
By their numbers in this assay, from the lowest: compounds 3 and 1 (each within the scatter of the next); then compound 2; then compound 4.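

In this assay, for the compounds shown here, benzylsulfanyl in place of ethylamino on the aromatic carbon next to the ring nitrogen gives a number 26 percentage points higher from compound 1 to compound 4 (beyond the scatter), and this is the first change at this position that can be read in a single place on the shared core. It shows that this position accepts the larger group, which brings a six-membered aromatic ring of carbon only and no hydrogen-bond donor, with a rise rather than a loss in inhibition at the concentration tested. Nothing measured here bears on why the number rises.

Going by these compounds alone, the single step changes the sulfur, the benzyl ring and the donor together, so it remains open which of them carries the rise. Methylsulfanyl or benzylamino at the same position would separate the sulfur from the aromatic ring.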